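Ester to Methylamide on a Pyridine-Linked Vinyl Chain

This account rests on a few compounds, and the source may have more. Where it says the series, first, only, none or still open, it means among the compounds named here.

Three compounds share a core in which a pyridine carries both an unsaturated side chain and an aromatic bicyclic group. Compound 1 is `CCOC(=O)/C=C/c1ccncc1-c1ccc2c(cnn2C)c1`; in an assay on a protein complex for inhibition of CDK8/Cyclin C (Homo sapiens), with a stated time of 1 h, tested at 10 uM (a higher number here means more inhibition at the concentration tested (going by the name of the read-out), a lower number less inhibition), compound 1 gives 100%. Compound 2, `CCOC(=O)/C=C/c1ccncc1-c1ccc2cc[nH]c2c1`, gives 104% in this assay, and compound 3, `COC(=O)/C=C/c1ccncc1-c1ccc2ccccc2c1`, gives 102%. Compound 1 has the lowest of the three numbers, but the gaps to compound 3 and to compound 2 both lie within the usual scatter, so the three numbers stand level in this assay.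

Compound 4 is `CNC(=O)/C=C/c1ccncc1-c1ccc2c(cnn2C)c1`, not yet measured in this assay. Compared with compound 1 it differs in one place: methylamino in place of ethoxy on a carbonyl carbon. Among the compounds with values here, no measured pair here carries such a change, so nothing among the measured compounds tells how large a step to expect. Since compound 1 already gives 100%, the step from compound 1 to compound 4 is expected to be small or none beyond the scatter, with some chance of a modest downward move: a number 6 percentage points lower from compound 1 to compound 4 (within the scatter). Compound 4 is estimated at 94%, within a range from 72% to 106%.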

Compound 4, a percentage reported as inhibition, at one concentration (the size of the read-out at that concentration, not a potency): 98%
Beside the measured number, compound 4's estimate is 4 percentage points below it; the range from low to high includes it.
By their numbers in this assay, from the lowest: compounds 4, 1, 3 and 2 (each within the scatter of the next).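

Within the data shown here, putting methylamino in place of ethoxy on a carbonyl carbon gives a number 2 percentage points lower from compound 1 to compound 4 (within the scatter) in this assay, the only direct comparison of a change at this position. On the core of compound 1, then, the ethyl ester is not required for this read-out at the one concentration tested, and the amide, with its hydrogen-bond donor, stands level with it. Nothing in the data shown explains this level result.

A single concentration gives the size of the read-out and not a potency, so a real difference in potency between the ester and the amide could stay hidden. Also open, as far as these compounds go, is how a carboxylic acid or a longer chain on the same carbonyl carbon would read, and whether methylamino would behave the same way on the cores of compound 2 and compound 3.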